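The source may hold more compounds than are shown below. What is called first, only, known or untested is meant among the compounds shown, and "the series" means these compounds.

Compound 1 `O=C1N=C(N2CCOCC2)CN1c1ccccc1`: 121 mg/kg in a functional assay on the whole organism (strain NMRI BR) with Mus musculus as the target; a lower number here means that less compound is needed, a higher number that more compound is needed for the effect.
Compound 2 `CN(C)C1=NC(=O)N(c2ccc(Cl)cc2)C1`: > 300 mg/kg, which is a limit of this assay and not a number.
Compound 3 `CC(c1ccccc1)N1CC(N2CCOCC2)=NC1=O`: > 300 mg/kg, likewise a limit of this assay and not a number.

Among these three results, compound 1 is the only one with a number attached; the other two sit at the limit of > 300 mg/kg in this assay, at which 2 of the 3 values shown sit. So compound 1 is the sole fixed point from which any expectation can start, and it stands alone without a measured neighbour that differs in a single place.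

The compound still to be tested is compound 4 `O=C1N=C(N2CCOCC2)CN1c1ccc(Br)cc1`. It differs from compound 1 by bromo in place of hydrogen on an aromatic carbon, that is, a bromo in place of hydrogen on an aromatic carbon. Nothing measured here shows what such a change does to the dose, so the step can only be guessed. The expected step is a 1.5-fold higher number from compound 1 to compound 4 (0.17 log units; within the scatter), a modest move towards a higher dose that may not exceed the usual scatter. Compound 4 is therefore expected to give 180 mg/kg, with the estimate running from 70 mg/kg to 500 mg/kg.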

Compound 4, dose for half-maximal effect: 21.8 mg/kg
The estimate for compound 4 lay 8.3-fold (0.92 log units) above the measured number; measured number outside the range, below it.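

In this assay, bromo in place of hydrogen on an aromatic carbon, para to a large group, brings a 5.6-fold lower number from compound 1 to compound 4 (0.74 log units; beyond the scatter). Among these compounds, this is the first step here that can be read, and it shows that the change at this place on the six-membered aromatic ring of carbon only goes towards less compound being needed for the effect. It rests on a single pair, so it shows the direction and size of this one change but not the reason for it.

On these data alone, whether fluorine, a methyl group or a methoxy group at the same place would act like bromo remains open. Steps to the other compounds cannot be read, as those compounds carry a limit of the assay and not a number: the limit of > 300 mg/kg in this assay, at which 2 of the 4 values shown sit.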